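This account rests on a few compounds, and the source may have more. Where it says the series, first, only, none or still open, it means among the compounds named here.

Compound 3 `O=C(O)CCCSCCN1C(=O)SC[C@@H]1/C=C/[C@@H](O)Cc1ccccc1` gives the lowest of the three numbers measured in an assay on CHO cells for displacement of a labelled ligand from prostaglandin E2 receptor EP3 subtype (Mus musculus), read by scintillation counting, with a stated time of 60 min (on this read-out lower numbers stand for stronger inhibition and higher numbers for weaker inhibition), at 39 nM. For the measured compounds named here, compound 2 `O=C(O)CCCSCCN1C(=O)OC[C@@H]1/C=C/[C@@H](O)Cc1cccc(C(F)(F)F)c1` gives 1600 nM in this assay, and compound 1 `CCCc1cccc(C[C@H](O)/C=C/[C@H]2CCC(=S)N2CCCCCCC(=O)O)c1` gives 2000 nM; both of these stand well beyond the scatter from compound 3, and neither differs from it in only one place, so their numbers show no single step. Compound 4 `CCCc1cccc(C[C@H](O)/C=C/[C@H]2CSC(=O)N2CCSCCCC(=O)O)c1` differs from compound 3 by propyl in place of hydrogen on an aromatic carbon. Going by the values given here, no measured pair isolates this change, and compound 1 carries the same propyl group on a different core. The step from compound 3 to compound 4 in this assay is therefore expected to stay small, about a 1.3-fold lower number from compound 3 to compound 4 (0.11 log units; within the scatter), in either direction or none beyond the scatter. Compound 4 is estimated at 30 nM, within 8 nM to 120 nM.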

Compound 4, inhibition constant: 1200 nM
For compound 4 the middle estimate is 40-fold (1.60 log units) below the measured one, and the stated range ends below it.
By their numbers in this assay, from the lowest: compound 3; then compounds 4, 2 and 1 (each within the scatter of the next).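

Replacing hydrogen with propyl on this aromatic carbon gives a 31-fold higher number from compound 3 to compound 4 (1.49 log units; beyond the scatter) in this assay. For the compounds shown here, this is the first single-place comparison, and it shows that, on the core shared by these two compounds, this change at this position is far from neutral. No measurement shown bears on why the number rises.

From the compounds shown here alone, whether methyl or a methoxy group at this same carbon would give a step of similar size remains open. So does whether removing the propyl group from compound 1 would have a comparable effect on its different core.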